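The compounds below may be only part of what the source reports. "The series", "measured", "known", "first", "only" and "open" are said of these compounds alone.

Compound 1 `COc1cc([N+](=O)[O-])ccc1NC(=S)NC(=O)c1ccccc1`: 1650 nM
Compound 2 `CCOc1ccc(OCC)c(NC(=S)NC(=O)c2ccccc2)c1`: 2040 nM
Compound 3 `CC(=O)NC(=S)NC(C)(C)C`: 2700 nM

All three numbers come from an assay for inhibition of epoxide hydrolase 1 (Homo sapiens), read by fluorescence, using microsomes; a higher number here means a weaker inhibitor, a lower number a stronger inhibitor. Compound 1 stands lowest of the three, yet compound 2 and compound 3 both lie within the scatter of it, so no order among them is claimed. Compound 4, `COc1cc([N+](=O)[O-])ccc1NC(=S)NC(C)=O`, has not yet been measured in this assay. Its difference from compound 1 is methyl in place of phenyl on a carbonyl carbon. Going by the values given here, no measured pair shows this change on its own; compound 3, which also carries methyl on its carbonyl carbon but against a different partner, gives 2700 nM. The step is therefore expected to be small and toward a higher number, if beyond the scatter at all; the expected step is a 1.5-fold higher number from compound 1 to compound 4 (0.18 log units; within the scatter). Compound 4 is estimated at 2500 nM, within 1000 nM to 6500 nM.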

Compound 4, half-maximal inhibitory concentration: 1870 nM
The estimate for compound 4 lay 1.3-fold (0.13 log units) above the measured number, and the stated range covers the measured number.
By their numbers in this assay, from the lowest: compounds 1, 4, 2 and 3 (each within the scatter of the next).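

In this assay, going by these compounds alone, methyl in place of phenyl on a carbonyl carbon gives a 1.1-fold higher number from compound 1 to compound 4 (0.05 log units; within the scatter), a step that no earlier pair showed on its own. At this place in the core of compound 1, the six-membered aromatic ring is therefore not needed for a number in this range. Nothing available bears on why this change is tolerated.

Still open, as far as these compounds go, is how an amine, a carboxylic acid or a longer chain would read on this carbonyl carbon. From the compounds shown here alone, whether the same change holds on the core of compound 2 is also open.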